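A Group Exchanged on an Amide-Type Nitrogen

The source may report more compounds than this note shows. Statements on the series, on what has been measured and on what is new or still open speak of the compounds shown alone.

In an ADME assay on MT4 cells (Homo sapiens) for cytotoxicity, with a stated time of 5 days (on this read-out lower numbers stand for higher toxicity in this test and higher numbers for lower toxicity in this test), compound 1 (`CC(C)N(c1cc(C#CC(C)(C)C)sc1C(=O)O)C(=O)[C@H]1CC[C@H](C)CC1`) gives > 20000 nM as a limit of the assay, not as a number. Going by these compounds, compound 2 (`CC(C)(C)C#Cc1cc(N(C(=O)[C@H]2CC[C@H](C)CC2)[C@H]2C[C@@H](Oc3cccnc3)C2)c(C(=O)O)s1`) gives > 20000 nM as a limit too, so its true value remains unknown. So far there is no exact number, only (the limit of > 20000 nM in this assay, at which 2 of the 2 values shown sit). Within the data shown here, with 3-((pyridin-3-yl)oxy)cyclobutyl in place of isopropyl on an amide-type nitrogen, the one measured step is (a step that the two limits leave unreadable from compound 1 to compound 2). Its size therefore offers no number to carry forward.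

Compound 3 (`CON=C1CCC(N(c2cc(C#CC(C)(C)C)sc2C(=O)O)C(=O)[C@H]2CC[C@H](C)CC2)CC1`) differs from compound 2 on that same nitrogen (a group of 9 heavy atoms (7 carbon, 1 nitrogen, 1 oxygen; one six-membered non-aromatic ring of carbon only) in place of a group of 11 heavy atoms (9 carbon, 1 nitrogen, 1 oxygen; one four-membered non-aromatic ring of carbon only, one six-membered aromatic ring with 1 hetero atom), on an amide-type nitrogen). Among the measured compounds shown here, with (a step that the two limits leave unreadable from compound 1 to compound 2) as the only guide, no drop beyond the usual scatter is expected, and no direction can be given with any confidence. The expected change is (a step that the limit leaves unreadable from compound 2 to compound 3), a step too small to count as a real rise or fall. Compound 3 is estimated at 22000 nM with a range from 10000 nM to 50000 nM and is expected to be reported most likely as a limit rather than a number.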

Compound 3, half-maximal cytotoxic concentration: > 20000 nM
Compound 3: only a limit was reported; the forecaster's own chance of this, stated with the estimate: 85%; the middle value is on the limit's open side.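

Compound 3 also gives only a limit in this assay, so the steps among compound 1, compound 2 and compound 3 cannot be read. All that can be stated is this: the limit of > 20000 nM in this assay, at which 3 of the 3 values shown sit. The compounds shown leave open how far apart their true values lie, and whether the group on the amide-type nitrogen changes them at all.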